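Swapping the Ring on the Aromatic Nitrogen for a Chain

This account rests on a few compounds, and the source may have more. Where it says the series, first, only, none or still open, it means among the compounds named here.

Three measured compounds share one core and differ only in the group on the aromatic nitrogen. Compound 1 `O=c1c(S(=O)(=O)c2ccc(F)cc2F)cc2cnc(Nc3ccc4[nH]ccc4c3)nc2n1CC1CC1` carries cyclopropylmethyl, and in a functional assay on K562 cells (Homo sapiens) for inhibition, read by trypan blue exclusion, with a stated time of 72 h (a lower number here means a stronger inhibitor, a higher number a weaker inhibitor), compound 1 gives 1000 nM. Compound 2 `O=c1c(S(=O)(=O)c2ccc(F)cc2F)cc2cnc(Nc3ccc4[nH]ccc4c3)nc2n1C1CCCCC1` carries cyclohexyl, and compound 2 gives 10000 nM. Compound 3 `O=c1c(S(=O)(=O)c2ccc(F)cc2F)cc2cnc(Nc3ccc4[nH]ccc4c3)nc2n1C1CCCC1` carries cyclopentyl, and compound 3 gives 5000 nM. Compound 3 thus holds the second highest of the three numbers: the step of a 5.0-fold higher number from compound 1 to compound 3 (0.70 log units; beyond the scatter) lies beyond the scatter, whereas the step of a 2.0-fold lower number from compound 2 to compound 3 (0.30 log units; within the scatter) does not. The step of a 10-fold higher number from compound 1 to compound 2 (1.00 log units; beyond the scatter) is the largest seen.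

Compound 4 `COC(=O)Cn1c(=O)c(S(=O)(=O)c2ccc(F)cc2F)cc2cnc(Nc3ccc4[nH]ccc4c3)nc21` has not yet been measured. It differs from compound 3 in this way: (methoxycarbonyl)methyl in place of cyclopentyl on an aromatic nitrogen. All three measured steps concern this same position, and they show that exchanging one ring for another there shifts the number only modestly, with cyclopropylmethyl giving the lowest number. Within the data shown here, in compound 4 a chain replaces the ring, and no measured step covers such an exchange, so the expectation is held loosely. Compound 4 is expected to give 3000 nM, with a range from 800 nM to 12000 nM. The expected step of a 1.7-fold lower number from compound 3 to compound 4 (0.22 log units; within the scatter) is a modest lowering, likely within the scatter.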

Compound 4, half-maximal inhibitory concentration: 5000 nM
The estimate for compound 4 lay 1.7-fold (0.22 log units) below the measured number; the measured number falls inside the stated range.
By their numbers in this assay, from the lowest: compound 1; then compounds 3, 4 and 2 (each within the scatter of the next).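

In this assay, among these compounds, the first exchange of a ring for a chain at this position gives no change at the digits printed from compound 3 to compound 4 (within the scatter), so replacing cyclopentyl with (methoxycarbonyl)methyl, which has the same count of heavy atoms but no ring and 2 hydrogen-bond acceptors, brings no readable shift. The comparison with the larger ring, a 2.0-fold lower number from compound 2 to compound 4 (0.30 log units; within the scatter), is also within the scatter, which places compound 4 with compounds 2 and 3, whereas a 5.0-fold higher number from compound 1 to compound 4 (0.70 log units; beyond the scatter) lies beyond it. Compounds 1 and 4 both attach a saturated chain carbon to the aromatic nitrogen and differ in what that carbon carries, so this carbon alone does not go with the lowest number, although no evidence here explains the difference.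

On these data alone, it remains open whether a carboxylic acid or a primary amide in place of methoxycarbonyl, or a plain ethyl or longer alkyl chain on the same carbon, would give a number nearer that of compound 1 or that of compound 4. Also open, as far as these compounds go, is whether a cyclobutylmethyl or cyclopentylmethyl group would keep the lower number seen with cyclopropylmethyl.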